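Lengthening a Methyl to Ethyl on Compound 3

The compounds below may be only part of what the source reports. "The series", "measured", "known", "first", "only" and "open" are said of these compounds alone.

Three ureas share one core. Compound 1 `Cc1ccc(NC(=O)Nc2cccc(CNc3nccnc3Cl)c2)cc1` gives 9820 nM in a functional assay on T-24 cells (Homo sapiens) for antiproliferative activity, read by MTT assay, with a stated time of 48 h; on this read-out lower numbers stand for stronger inhibition and higher numbers for weaker inhibition. Compound 2 `Cc1ccc(NC(=O)Nc2cccc(CNc3nccnc3Cl)c2)c(C)c1` gives 9230 nM in this assay, and compound 3 `Cc1ccccc1NC(=O)Nc1cccc(CNc2nccnc2Cl)c1` gives 13600 nM. Compound 3 stands at the highest of the three numbers, yet its gaps to compound 1 and to compound 2 are both within the scatter, so the three read as alike. Compound 4 `CCc1ccccc1NC(=O)Nc1cccc(CNc2nccnc2Cl)c1` differs from compound 3 by methyl in place of hydrogen on a saturated chain carbon bound to an aromatic carbon. Among the measured compounds shown here, the only measured step that resembles this, a methyl in place of hydrogen on an aromatic carbon, is a 1.1-fold lower number from compound 1 to compound 2 (0.03 log units; within the scatter); no measured step touches a chain carbon. A step of that kind is therefore expected, namely a 1.0-fold lower number from compound 3 to compound 4 (0.02 log units; within the scatter), nothing beyond the scatter. Compound 4 is accordingly estimated at 13000 nM, within a range from 5000 nM to 32000 nM.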

Compound 4, half-maximal inhibitory concentration: 8720 nM
For compound 4 the middle estimate is 1.5-fold (0.17 log units) above the measured one; measured number inside the range.
By their numbers in this assay, from the lowest: compounds 4, 2, 1 and 3 (each within the scatter of the next).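

Adding one carbon at this saturated chain carbon, turning methyl into ethyl, gives a 1.6-fold lower number from compound 3 to compound 4 (0.19 log units; within the scatter) in this assay and is the only measured step at such a carbon, so this position tolerates ethyl with no change beyond the scatter. The comparisons with the other aryl groups agree, with a 1.1-fold lower number from compound 2 to compound 4 (0.02 log units; within the scatter) and a 1.1-fold lower number from compound 1 to compound 4 (0.05 log units; within the scatter) both also within the scatter. No measured evidence explains this result.

Among the compounds shown here, with every step so far within the scatter, it remains open how much this position matters. A longer propyl chain, an amine or a carboxylic acid on this carbon could show whether any group here moves the number beyond the scatter.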